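From ethoxycarbonyl to sec-butoxycarbonyl: working notes

The source may report more compounds than this note shows. Statements on the series, on what has been measured and on what is new or still open speak of the compounds shown alone.

Measured in a functional assay on the whole organism for inhibition, with Scenedesmus acutus as the target; on this read-out higher numbers stand for weaker inhibition and lower numbers for stronger inhibition:
- compound 1 `O=C(O)c1cc(N2C(=O)C3=C(CCCC3)C2=O)c(F)cc1Cl`: 1000 nM
- compound 2 `CCOC(=O)c1cc(N2C(=O)C3=C(CCCC3)C2=O)c(F)cc1Cl`: 57.5 nM
- compound 3 `CCOC(=O)c1cc(N2C(=O)C3=C(CCCC3)C2=O)ccc1Cl`: 1910 nM

Compound 3, at 1910 nM, sits level with compound 1 within the scatter, and the two lie well apart from compound 2. The gap is a 33-fold higher number from compound 2 to compound 3 (1.52 log units; beyond the scatter), with hydrogen in place of fluoro on an aromatic carbon.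

The next structure is compound 4 `CCC(C)OC(=O)c1cc(N2C(=O)C3=C(CCCC3)C2=O)ccc1Cl`. The change is ethyl in place of hydrogen on a saturated chain carbon bound to an oxygen next to a carbonyl group and a saturated chain carbon, which turns ethoxycarbonyl into sec-butoxycarbonyl.

Among the compounds with values here, no measured step alters this chain carbon. The closest is a 17-fold lower number from compound 1 to compound 2 (1.24 log units; beyond the scatter), with ethyl in place of hydrogen on an oxygen next to a carbonyl group. That large step was made on the oxygen itself and in fluoro compounds, so it offers only a weak lean towards a lower number in this assay. No step beyond the scatter is expected. The estimated step is a 1.4-fold lower number from compound 3 to compound 4 (0.13 log units; within the scatter). For compound 4 the estimated value is 1400 nM, with an expected range of 500 nM to 3500 nM.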

Compound 4, half-maximal inhibitory concentration: 1100 nM
The estimate for compound 4 lay 1.3-fold (0.10 log units) above the measured number, within the range that was stated.
By their numbers in this assay, from the lowest: compound 2; then compounds 1, 4 and 3 (each within the scatter of the next).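

In this assay, within the data shown here, the first change on this saturated chain carbon gives a 1.7-fold lower number from compound 3 to compound 4 (0.24 log units; within the scatter), so in the compounds with hydrogen on the aromatic carbon, going from ethoxycarbonyl to sec-butoxycarbonyl leaves the number within the scatter. This position therefore takes an added ethyl without a step of the size seen for a 17-fold lower number from compound 1 to compound 2 (1.24 log units; beyond the scatter) or a 33-fold higher number from compound 2 to compound 3 (1.52 log units; beyond the scatter). Nothing available explains why this step stays small.

Open, on these data alone, is whether sec-butoxycarbonyl is equally neutral with fluoro on the aromatic carbon, the setting in which compound 2 gives 57.5 nM. Also open, as far as these compounds go, is how a longer chain such as n-hexyl, a cyclohexyl group or an amide in place of the ester would read in this assay.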